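Pentyl on the Core of Compound 2: Toxicity Outlook

The compounds below may be only part of what the source reports. "The series", "measured", "known", "first", "only" and "open" are said of these compounds alone.

Measured compounds:
- compound 1, `Cc1cc(N2CC[C@@H](C)[C@@H](N(C)c3ncnc4[nH]ccc34)C2)n2nc(SCC3CC3)nc2n1`, 27900 nM
- compound 2, `Cc1cc(N2CC[C@@H](C)[C@@H](N(C)c3ncnc4[nH]ccc34)C2)n2nc(SCc3ccc(Cl)cc3)nc2n1`, gives only a limit in this assay
- compound 3, `Cc1cc(N2CC[C@@H](C)[C@@H](N(C)c3ncnc4[nH]ccc34)C2)n2nc(SCc3ccc(Br)cc3)nc2n1`, 55600 nM

In a toxicity assay on GES1 cells (Homo sapiens) for inhibition, read by MTT assay, with a stated time of 72 h (on this read-out higher numbers stand for weaker inhibition and lower numbers for stronger inhibition), compound 1 gives 27900 nM. Compound 2 reaches only the limit of the assay, > 100000 nM, so no number is known for it. Compound 3 gives 55600 nM. The steps among them are modest: an at least 3.5-fold higher number from compound 1 to compound 2 (0.55 log units; beyond the scatter), a 2.0-fold higher number from compound 1 to compound 3 (0.30 log units; within the scatter), and an at least 1.7-fold lower number from compound 2 to compound 3 (0.25 log units; that floor lies within the scatter), the last two within the scatter. Compound 2 thus stands at the weak end of what is shown, fixed only by the limit of > 100000 nM in this assay, at which 1 of the 3 values shown sits.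

Compound 4, `CCCCCc1c(C)nc2nc(SCc3ccc(Cl)cc3)nn2c1N1CC[C@@H](C)[C@@H](N(C)c2ncnc3[nH]ccc23)C1`, differs from compound 2 in one place: pentyl in place of hydrogen on an aromatic carbon. Among the compounds with values here, none of the measured steps touches this part of the shared core; all three change the group on the saturated chain carbon bound to a sulfur or a halogen on its ring. There is therefore no direct guide for the pentyl change, and no step beyond the scatter is expected in this assay. Compound 4 is estimated at 100000 nM, within 30000 nM to 300000 nM, which means an expected step of a number no higher from compound 2 to compound 4 (the limit leaves the size open), with a real chance that compound 4 again reports only a limit.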

Compound 4, half-maximal inhibitory concentration: > 100000 nM
Compound 4: a limit, no number; the forecaster's own chance of this, stated with the estimate: 60%; the middle value sits exactly at the limit.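

Compound 4 gives > 100000 nM in this assay, which is a limit and not a number. Compound 2 also stands at a limit, so no step can be read between compound 2 and compound 4: the limit of > 100000 nM in this assay, at which 2 of the 4 values shown sit.

On these data alone, what pentyl in place of hydrogen on this aromatic carbon does to the number in this assay stays open.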